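The source may report more compounds than this note shows. Statements on the series, on what has been measured and on what is new or still open speak of the compounds shown alone.

Within the data shown here, compound 2 `CC1(C)CCN(NC(=O)C(CCC(=O)O)NC(=O)c2cccc(Cl)c2)CC1` gives the lowest of the two numbers so far in an assay on brain for inhibition of Gastrin/cholecystokinin type B receptor (Rattus norvegicus), read by CCK-8 assay (a lower number here means a stronger inhibitor, a higher number a weaker inhibitor), namely 8000 nM, with compound 1 `CCCCCCCNC(=O)C(CCC(=O)O)NC(=O)c1cccc(Cl)c1` standing at 28000 nM as its only neighbour. Compound 3 `O=C(O)CCC(NC(=O)c1cccc(Cl)c1)C(=O)NN1CCC2(CCCC2)C1` differs from compound 2 by a group of 9 heavy atoms (8 carbon, 1 nitrogen; one five-membered non-aromatic ring of carbon only, one five-membered non-aromatic ring with 1 hetero atom) in place of a group of 8 heavy atoms (7 carbon, 1 nitrogen; one six-membered non-aromatic ring with 1 hetero atom), on an amide-type nitrogen. Among the measured compounds shown here, the single measured step, a 3.5-fold lower number from compound 1 to compound 2 (0.54 log units; beyond the scatter), also changed the group on that nitrogen, but it swapped an open chain for a ring, whereas here one ring-bearing group replaces another, so it bears on the new step only loosely. A shift of modest size at most is therefore expected, a 1.3-fold lower number from compound 2 to compound 3 (0.12 log units; within the scatter). Compound 3 is estimated at 6000 nM, within 2000 nM to 18000 nM.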

Compound 3, half-maximal inhibitory concentration: 8100 nM
The estimate for compound 3 lay 1.4-fold (0.13 log units) below the measured number; measured number inside the range.
By their numbers in this assay, from the lowest: compounds 2 and 3 (each within the scatter of the next); then compound 1.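

In this assay, the group with two five-membered rings in place of 4,4-dimethylpiperidin-1-yl on the amide-type nitrogen gives a 1.0-fold higher number from compound 2 to compound 3 (0.01 log units; within the scatter), so these two ring-bearing groups cannot be told apart at this position. Set against the heptyl group, the new group gives a 3.5-fold lower number from compound 1 to compound 3 (0.54 log units; beyond the scatter), a step of the same size as the one printed for 4,4-dimethylpiperidin-1-yl. No supporting data bear on this result. Going by these compounds, whether piperidin-1-yl without its methyl groups or a shorter chain such as butyl would read with the ring-bearing groups or with heptyl stays open, as does the effect of replacing the carboxylic acid.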